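A few compounds are considered here, and "the series" means these few. Any claim that something is new, unique, unknown or untested is made for them only; others in the source may bear on it.

Measured so far:
Compound 1, `O=C(Nc1ccc([N+](=O)[O-])cc1Cl)c1cccc2cc[nH]c12` — < 1 ug/mL
Compound 2, `N#Cc1ccc(NC(=O)c2cc(Cl)ccc2O)c(Cl)c1` — < 1 ug/mL

Of the compounds shown here, two have been measured in a physicochemical assay for solubility (on this read-out higher numbers stand for higher solubility and lower numbers for lower solubility), and neither has given a number. For compound 1 the reading of < 1 ug/mL is a limit of the assay, not a measured value. For compound 2 the reading of < 1 ug/mL is likewise a limit, so compound 2 stands at the floor of what the assay can report, and nothing separates it from compound 1 on these numbers. Within the data shown here, the only evidence about where the compounds sit is the limit of < 1 ug/mL in this assay, at which 2 of the 2 values shown sit.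

Compound 3, `O=C(Nc1ccc(Cl)cc1Cl)c1cc(Cl)ccc1O`, has not yet been measured. It is derived from compound 2 by a single change: chloro in place of cyano on an aromatic carbon. Among the measured compounds shown here, compound 2 already sits at a limit, and no measured step exists to guide the direction, so the step from compound 2 to compound 3 is expected to be small or none beyond the scatter, most likely leaving compound 3 at the same limit. The solubility of compound 3 in this assay is estimated at 0.5 ug/mL, with a range from 0.1 ug/mL to 3 ug/mL, which would mean a step that the limit leaves unreadable from compound 2 to compound 3.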

Compound 3, solubility: < 1 ug/mL
Compound 3: only a limit was reported; the forecaster's own chance of this, stated with the estimate: 70%; the middle value is on the limit's open side.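

In this assay, compound 3 gives < 1 ug/mL, which is a limit of the assay and not a number. Compound 2 also stands at a limit, so no step can be read between compound 2 and compound 3. The compounds shown leave open how soluble each one actually is and whether chloro in place of cyano changes the read-out at all, as all of them share one reading: the limit of < 1 ug/mL in this assay, at which 3 of the 3 values shown sit.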